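The source may report more compounds than this note shows. Statements on the series, on what has been measured and on what is new or still open speak of the compounds shown alone.

Compound 1 `CCCc1nn(C)c2c(NCc3ccc(F)cc3)nc(/C=C/c3nc(C)c(C)nc3C)nc12`: > 1000000 nM
Compound 2 `CCCc1nn(C)c2c(NC3CC3)nc(/C=C/c3cccnc3)nc12`: 261000 nM
Compound 3 `CN(C)c1nc(/C=C/c2ccccc2)nc2ccsc12`: > 1000000 nM
Compound 4 `CN(c1ccccc1)c1nc(/C=C/c2ccccc2)nc2ccsc12`: not yet measured

These results come from a functional assay on L02 cells (Homo sapiens) for inhibition, read by Griess assay, with stated times of 1 h and 24 h; on this read-out lower numbers stand for stronger inhibition and higher numbers for weaker inhibition. Compound 3 gives > 1000000 nM, which is a limit and not a number. Compound 1 also gives only a limit, > 1000000 nM. Compound 2 alone gives a number, 261000 nM. Compound 4 carries phenyl in place of methyl on a nitrogen on an aromatic ring, dimethylamino to methyl(phenyl)amino: phenyl in place of methyl on a nitrogen on an aromatic ring. Among the measured compounds shown here, no measured pair shows this change, so the expectation is loose. The estimated step of an at least 1.4-fold lower number from compound 3 to compound 4 (0.15 log units; that floor lies within the scatter) is small and towards stronger inhibition, if it can be seen at all, and a further limit is quite possible. For compound 4 the expected value is 700000 nM, with an estimated range of 200000 nM to 1500000 nM.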

Compound 4, half-maximal inhibitory concentration: > 1000000 nM
Compound 4: a limit, no number; the forecaster's own chance of this, stated with the estimate: 60%; middle value at least 1.4-fold (0.15 log units) away from the limit.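

Compound 4 gives > 1000000 nM, a limit and not a number. Among the compounds shown here, compound 3 also gives only a limit, so no step from compound 3 to compound 4 can be read. The compounds shown leave open whether phenyl in place of methyl on a nitrogen on an aromatic ring changes inhibition at all.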